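Loss of the ring-nitrogen acyl group: cytotoxicity notes

The source may report more compounds than this note shows. Statements on the series, on what has been measured and on what is new or still open speak of the compounds shown alone.

Measured compounds:
compound 1 `O=C(Nc1cc(C(F)(F)F)cc(C(F)(F)F)c1)C1CCc2ccccc2N1C(=O)c1ccc(Cl)cc1` — 4230 nM
compound 2 `CCCC(=O)N1c2ccccc2CCC1C(=O)Nc1cc(C(F)(F)F)cc(C(F)(F)F)c1` — 18600 nM
compound 3 `O=C(Nc1cc(C(F)(F)F)cc(C(F)(F)F)c1)C1CCc2ccccc2N1C(=O)c1ccccc1` — 3500 nM

In a functional assay on PC-3 cells (Homo sapiens) for cytotoxicity, read by sulforhodamine B assay, with a stated time of 72 h (a higher number here means a weaker inhibitor of growth, a lower number a stronger inhibitor of growth), compound 3 gives 3500 nM, the lowest of the three numbers. The step of a 1.2-fold lower number from compound 1 to compound 3 (0.08 log units; within the scatter) lies within the scatter, so compound 3 and compound 1 cannot be ordered; the step of a 5.3-fold lower number from compound 2 to compound 3 (0.73 log units; beyond the scatter) lies beyond it.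

Compound 4 `O=C(Nc1cc(C(F)(F)F)cc(C(F)(F)F)c1)C1CCc2ccccc2N1` differs from compound 3 by hydrogen in place of benzoyl on a nitrogen on an aromatic ring in a ring. Among the measured compounds shown here, no measured step removes the acyl group altogether. For the measured compounds named here, the steps that bear on it are a 4.4-fold higher number from compound 1 to compound 2 (0.64 log units; beyond the scatter) and a 5.3-fold lower number from compound 2 to compound 3 (0.73 log units; beyond the scatter): both show that the two aryl acyl groups give lower numbers than the propyl acyl, and the bare hydrogen is a further departure from that pattern with no direct precedent among the three. The direction is therefore expected to be upward in this assay, and the step of a 7.1-fold higher number from compound 3 to compound 4 (0.85 log units; beyond the scatter) is estimated to be at least as large as the propyl case. Compound 4 is expected in this assay to give about 25000 nM, with a range from 8000 nM to 80000 nM.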

Compound 4, concentration for 50% growth inhibition: 8120 nM
Estimate against measurement, compound 4: 3.1-fold (0.49 log units) above; measured number inside the range.
By their numbers in this assay, from the lowest: compounds 3, 1 and 4 (each within the scatter of the next, the first and the last beyond it); then compound 2.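

In this assay the acyl group on this nitrogen is not needed for growth inhibition, since removing benzoyl gives only a 2.3-fold higher number from compound 3 to compound 4 (0.37 log units; beyond the scatter) and leaves a modest loss. Removing (4-chlorophenyl)carbonyl gives a 1.9-fold higher number from compound 1 to compound 4 (0.28 log units; within the scatter) and so cannot be ordered, whereas removing propylcarbonyl gives a 2.3-fold lower number from compound 2 to compound 4 (0.36 log units; beyond the scatter) and is a modest gain. An acyl group here can therefore sit on either side of the bare hydrogen: benzoyl gives the lower number and propylcarbonyl the higher, with (4-chlorophenyl)carbonyl going against any clean split of aryl acyl groups from hydrogen.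

Open, going by these compounds, is how a methyl group, an acetyl group or a benzoyl group carrying an amine on its ring would fall on this nitrogen. Nothing beyond the growth numbers bears on why these groups fall as they do.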